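Two hydroxyphenyl isomers on a pyridin-3-yl core

The source may report more compounds than this note shows. Statements on the series, on what has been measured and on what is new or still open speak of the compounds shown alone.

Measured compounds:
- compound 1, `Oc1ccc(-c2cc(-c3ccco3)cc(-c3cccc(O)c3)n2)cc1`: 100%
- compound 2, `Oc1ccc(-c2cc(-c3ccco3)cc(-c3ccc(O)cc3)n2)cc1`: 100%
- compound 3, `Oc1ccc(-c2cc(-c3cccnc3)cc(-c3cccc(O)c3)n2)cc1`: 5.9%

In an assay on isolated protein for inhibition of DNA topoisomerase 1 (Homo sapiens), with a stated time of 30 min, tested at 100 uM (on this read-out higher numbers stand for a stronger effect at the one concentration tested and lower numbers for a weaker effect), compound 1 gives 100% and compound 2 gives 100%; the change between them is 4-hydroxyphenyl in place of 3-hydroxyphenyl on an aromatic carbon, and the step is no change at the digits printed from compound 1 to compound 2 (within the scatter). Compound 3 carries a different core, the difference being (pyridin-3-yl in place of furan-2-yl on an aromatic carbon), and in this assay compound 3 gives 5.9%; the step is a number 94.1 percentage points lower from compound 1 to compound 3 (beyond the scatter), the lowest number of the three.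

Compound 4, `Oc1ccc(-c2cc(-c3cccnc3)cc(-c3ccc(O)cc3)n2)cc1`, has not been measured. It differs from compound 3 by 4-hydroxyphenyl in place of 3-hydroxyphenyl on an aromatic carbon, the same kind of change as that from compound 1 to compound 2; what differs around the place is that in compound 1 the position is meta to a furan-2-yl group (5 heavy atoms), whereas in compound 3 it is meta to a pyridin-3-yl group (6 heavy atoms).

Among the measured compounds shown here, the only evidence for this kind of change is no change at the digits printed from compound 1 to compound 2 (within the scatter), which lay within the scatter, although both numbers there were at the top of the scale. For compound 4 the step is therefore expected to be small, about a number 2.1 percentage points higher from compound 3 to compound 4 (within the scatter) in this assay, resting on the low number of compound 3 at 5.9%. Compound 4 is estimated at 8%, between 0% and 30%.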

Compound 4, a percentage reported as inhibition, at one concentration (the size of the read-out at that concentration, not a potency): 8.7%
For compound 4 the middle estimate is 0.7 percentage points below the measured one, and the stated range covers the measured number.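

In this assay, among the compounds shown here, the change from 3-hydroxyphenyl to 4-hydroxyphenyl on the core of compound 3 is a number 2.8 percentage points higher from compound 3 to compound 4 (within the scatter), and this agrees with the same change on the core of compound 1: the same change on two cores in this assay, no change at the digits printed (within the scatter) from compound 1 to compound 2 and a number 2.8 percentage points higher (within the scatter) from compound 3 to compound 4, 2.8 percentage points apart, within the scatter of two such steps The other change also carries across, with pyridin-3-yl in place of furan-2-yl being a number 91.3 percentage points lower from compound 2 to compound 4 (beyond the scatter), which matches the step seen with the 3-hydroxyphenyl compounds: the same change on two cores in this assay, a number 94.1 percentage points lower (beyond the scatter) from compound 1 to compound 3 and a number 91.3 percentage points lower (beyond the scatter) from compound 2 to compound 4, 2.8 percentage points apart, within the scatter of two such steps This agreement rests on only two cores and a single concentration, and compound 1 gives 100% while compound 2 gives 100%, both at the top of the scale, so any difference between these two could stay hidden and neither the hydroxyphenyl step nor the agreement says anything about potency.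

The compounds shown leave open whether the large drop is specific to pyridin-3-yl or would also appear with other groups at that place, such as thiophen-2-yl or a plain phenyl. They also leave open what would happen on either core if the hydroxyl of the hydroxyphenyl groups gave way to a methoxy group or an amine.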